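Compound 3: a methyl on the chain of compound 2

The source may report more compounds than this note shows. Statements on the series, on what has been measured and on what is new or still open speak of the compounds shown alone.

In an ADME assay on MT4 cells (Homo sapiens) for cytotoxicity, read by MTT assay (on this read-out higher numbers stand for lower toxicity in this test and lower numbers for higher toxicity in this test), compound 1 (`Cc1cc(C)cc(S(=O)(=O)c2c(C(=O)NC(C)c3ccccc3O)[nH]c3ccc(Cl)cc23)c1`) gives 21800 nM. Compound 2 (`Cc1cc(C)cc(S(=O)(=O)c2c(C(=O)NCC(=O)NCc3cccc(O)c3)[nH]c3ccc(Cl)cc23)c1`) gives > 47500 nM, which is a limit of the assay and not a number. That places compound 2 at the limit of > 47500 nM in this assay, at which 1 of the 2 values shown sits. Compound 3 (`Cc1cc(C)cc(S(=O)(=O)c2c(C(=O)NC(C)C(=O)NCc3cccc(O)c3)[nH]c3ccc(Cl)cc23)c1`) carries methyl in place of hydrogen on a saturated chain carbon bound to an amide-type nitrogen and a carbonyl carbon. Among the compounds with values here, only one measured step exists, an at least 2.1-fold higher number from compound 1 to compound 2 (0.33 log units; beyond the scatter), and it bears only loosely, as it exchanges a whole group on an amide-type nitrogen. Within the data shown here, no measured step shows the effect of a single methyl, so no change beyond the scatter is expected, and the estimated step is an at least 1.1-fold lower number from compound 2 to compound 3 (0.07 log units; that floor lies within the scatter). In this assay compound 3 is estimated at 40000 nM, with an expected range from 20000 nM to 60000 nM.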

Compound 3, half-maximal cytotoxic concentration: 23800 nM
Estimate against measurement, compound 3: 1.7-fold (0.23 log units) above, and the stated range covers the measured number.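

In this assay, within the data shown here, methyl in place of hydrogen on a saturated chain carbon bound to an amide-type nitrogen and a carbonyl carbon gives an at least 1.9-fold lower number from compound 2 to compound 3 (0.30 log units; that floor lies within the scatter), the only measured change at this place. The value of compound 2 is a limit of the assay and not a number, so the true size of this step cannot be fixed, and its floor alone can be read: the limit of > 47500 nM in this assay, at which 1 of the 3 values shown sits.

With the methyl present, (3-hydroxybenzyl)carbamoyl in place of 2-hydroxyphenyl on a saturated chain carbon bound to an amide-type nitrogen and a saturated chain carbon gives a 1.1-fold higher number from compound 1 to compound 3 (0.04 log units; within the scatter), so this exchange does not separate the two compounds in this test.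

As far as these compounds go, whether the methyl step truly lies beyond the scatter remains open. Also open, from the compounds shown here alone, is how an ethyl group, a longer chain or a carboxylic acid on this same carbon would read in this assay.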